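Benzyl for butyl on the amine of compound 1

This account rests on a few compounds, and the source may have more. Where it says the series, first, only, none or still open, it means among the compounds named here.

Compounds measured so far:
compound 1 `CCCCN(C)Cc1c(C(F)(F)F)nc2n(-c3c(C)cc(C)cc3C)c(Cl)cn12`, 310 nM
compound 2 `Cc1cc(C)c(-n2c(Cl)cn3c(CN(CCC4CC4)CCC(F)(F)F)c(C(F)(F)F)nc23)c(C)c1`, 110 nM
compound 3 `Cc1cc(C)c(-n2c(Cl)cn3c(CN(CCC(F)(F)F)Cc4ccc(Cl)cc4)c(C(F)(F)F)nc23)c(C)c1`, 12 nM

In an assay on cells for displacement of a labelled ligand from corticotropin-releasing factor receptor 1 (Homo sapiens), with a stated time of 100 min (a lower number here means a stronger inhibitor, a higher number a weaker inhibitor), compound 1 gives the highest of the three numbers, with compound 2 nearer to it and compound 3 far below. Compound 4 `Cc1cc(C)c(-n2c(Cl)cn3c(CN(C)Cc4ccccc4)c(C(F)(F)F)nc23)c(C)c1` differs from compound 1 by phenyl in place of propyl on a saturated chain carbon bound to an amine nitrogen. The nearest measured step is a 9.2-fold lower number from compound 2 to compound 3 (0.96 log units; beyond the scatter), where an aromatic ring also entered on a saturated chain carbon bound to an amine nitrogen; that ring carried a chlorine, and the other amine substituent differed, so the parallel is loose. A lower number is therefore expected for compound 4, by a 3.9-fold lower number from compound 1 to compound 4 (0.59 log units; beyond the scatter). Compound 4 is estimated at 80 nM, within 25 nM to 250 nM.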

Compound 4, inhibition constant: 160 nM
Beside the measured number, compound 4's estimate is 2.0-fold (0.30 log units) below it, and the stated range covers the measured number.
By their numbers in this assay, from the lowest: compound 3; then compounds 2, 4 and 1 (each within the scatter of the next, the first and the last beyond it).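

In this assay, phenyl in place of propyl on a saturated chain carbon bound to an amine nitrogen gives a 1.9-fold lower number from compound 1 to compound 4 (0.29 log units; within the scatter) and so stays within the scatter: with methyl as the other amine substituent, benzyl and butyl cannot be told apart. An aromatic ring alone therefore does not reproduce a 9.2-fold lower number from compound 2 to compound 3 (0.96 log units; beyond the scatter) here, a step that also involved a chlorine and a different amine partner. Nothing available bears on the reason for this. From the compounds shown here alone, it remains open whether 4-chlorobenzyl with methyl as the other amine substituent, or unsubstituted benzyl paired with 3,3,3-trifluoropropyl, would separate these contributions.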